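Swapping an Aromatic Amide for an Oxane Amide

The compounds below may be only part of what the source reports. "The series", "measured", "known", "first", "only" and "open" are said of these compounds alone.

Among the measured compounds shown here, compound 2 `CC(C)OC(=O)C1CN(C(=O)c2cccc(F)c2)CC(C)(C)c2cc(C#N)[nH]c21` carries a 3-fluorophenyl on the carbonyl carbon; in an assay on HEK293 cells for agonist activity at Bile acid receptor (Homo sapiens), read by a luciferase reporter (on this read-out higher numbers stand for an effect only at larger amounts of compound and lower numbers for an effect already at smaller amounts), compound 2 gives 1300 nM, one of only two numbers so far and within the scatter of the other. Its cyclohexyl counterpart, compound 1 `CC(C)OC(=O)C1CN(C(=O)C2CCCCC2)CC(C)(C)c2cc(C#N)[nH]c21`, gives 1900 nM in this assay, and the step of a 1.5-fold lower number from compound 1 to compound 2 (0.16 log units; within the scatter) is within the scatter. Compound 3 `CC(C)OC(=O)C1CN(C(=O)C2CCOCC2)CC(C)(C)c2cc(C#N)[nH]c21` differs from compound 2 by oxan-4-yl in place of 3-fluorophenyl on a carbonyl carbon. For the measured compounds named here, only that one small step bears on this change, so no shift beyond the scatter is expected in this assay. Compound 3 is therefore estimated at 2000 nM, between 800 nM and 5000 nM, a step of a 1.5-fold higher number from compound 2 to compound 3 (0.19 log units; within the scatter) expected in this assay.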

Compound 3, half-maximal effective concentration in the Bile acid receptor assay: 3300 nM
Beside the measured number, compound 3's estimate is 1.7-fold (0.22 log units) below it; the range from low to high includes it.
By their numbers in the Bile acid receptor assay, from the lowest: compounds 2, 1 and 3 (each within the scatter of the next, the first and the last beyond it).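

Among the compounds shown here, in the Bile acid receptor assay oxan-4-yl on this carbonyl carbon gives a 2.5-fold higher number from compound 2 to compound 3 (0.40 log units; beyond the scatter) as the first step here beyond the scatter, whereas a 1.7-fold higher number from compound 1 to compound 3 (0.24 log units; within the scatter) leaves oxan-4-yl and cyclohexyl within the scatter of each other. In a physicochemical assay for solubility, at pH 7.4 (a higher number here means a more soluble compound, a lower number a less soluble compound), compound 2 gives > 100 ug/mL as a limit of the assay. In the physicochemical assay compound 3 gives > 100 ug/mL as a limit too, and the step between the two cannot be read: the limit of > 100 ug/mL in the physicochemical assay, at which 2 of the 2 values shown sit.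

Left open is how a piperidin-4-yl or a pyridyl group on this carbonyl carbon would read in the Bile acid receptor assay and how far compound 2 and compound 3 lie apart in the physicochemical assay once measured without a limit.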